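Adding a long chain to the hydroxy group of compound 3

This account rests on a few compounds, and the source may have more. Where it says the series, first, only, none or still open, it means among the compounds named here.

In a functional assay on MDA-MB-231 cells (Homo sapiens) for antiproliferative activity, read by MTT assay, with a stated time of 48 h (on this read-out lower numbers stand for stronger inhibition and higher numbers for weaker inhibition), compound 1 `COc1ccc(N(C)c2ccnc(Cl)n2)cc1` gives 2820 nM and compound 2 `COc1ccc(N(C)c2ccnc(Cl)n2)cc1Cl` gives 1380 nM on the same scale. Compound 3 `COc1ccc(N(C)c2ccnc(Cl)n2)cc1O` gives 833 nM and so stands lower than compound 1, yet within the usual scatter of compound 2 (a 1.7-fold lower number from compound 2 to compound 3 (0.22 log units; within the scatter)). For the measured compounds named here, compound 4 `COc1ccc(N(C)c2ccnc(Cl)n2)cc1OCCC[Se]C#N` has a group of 6 heavy atoms (4 carbon, 1 nitrogen, 1 selenium; no ring) in place of a hydrogen atom, on an oxygen on an aromatic ring and no measured compound carries such a group. Going by the values given here, only two modest changes offer any guide (a 2.0-fold lower number from compound 1 to compound 2 (0.31 log units; beyond the scatter) and a 3.4-fold lower number from compound 1 to compound 3 (0.53 log units; beyond the scatter)), and neither replaces that hydrogen, so a similarly modest fall is expected, with wide uncertainty. The expected change in this assay is a 1.7-fold lower number from compound 3 to compound 4 (0.22 log units; within the scatter) for this step. Compound 4 is estimated at 500 nM (range 80 nM to 2500 nM).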

Compound 4, half-maximal inhibitory concentration: 1490 nM
Beside the measured number, compound 4's estimate is 3.0-fold (0.47 log units) below it, and the stated range covers the measured number.
By their numbers in this assay, from the lowest: compounds 3, 2, 4 and 1 (each within the scatter of the next, the first and the last beyond it).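

In this assay, replacing the hydrogen on the oxygen with a chain of 6 heavy atoms leaves the number within the scatter (a 1.8-fold higher number from compound 3 to compound 4 (0.25 log units; within the scatter)). For the compounds shown here, the other two comparisons also stay within the scatter (a 1.1-fold higher number from compound 2 to compound 4 (0.03 log units; within the scatter); a 1.9-fold lower number from compound 1 to compound 4 (0.28 log units; within the scatter)), so compound 4 cannot be separated from any of the earlier compounds, and this position accepts a much larger group without a clear change. No measurement here explains this result.
From the compounds shown here alone, whether the selenium atom or the nitrile matters remains open. A shorter chain, a longer chain, or a chain ending in an amine could test this.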